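Working notes: fluoro in place of cyano

A few compounds are considered here, and "the series" means these few. Any claim that something is new, unique, unknown or untested is made for them only; others in the source may bear on it.

- compound 1 `CC(C)(C)c1cc(Nc2ccc(Cl)cc2Cl)ncc1C(=O)NCC1CCOCC1`: 23 ug/mL
- compound 2 `N#Cc1cccc(Nc2cc(C3CC3)c(C(=O)NCC3CCOCC3)cn2)c1`: 4 ug/mL
- compound 3 `CC(C)(O)c1cc(Nc2ccc(Cl)cc2Cl)ncc1C(=O)NCC1CCOCC1`: 150 ug/mL

In a physicochemical assay for solubility, at pH 7.4 (on this read-out lower numbers stand for lower solubility and higher numbers for higher solubility), compound 2 gives 4 ug/mL, the lowest of the three. Compound 1 lies nearest at 23 ug/mL and compound 3 furthest at 150 ug/mL.

Compound 4 `O=C(NCC1CCOCC1)c1cnc(Nc2cccc(F)c2)cc1C1CC1` has fluoro in place of cyano on an aromatic carbon. Among the measured compounds shown here, the one measured step, a 6.5-fold higher number from compound 1 to compound 3 (0.81 log units; beyond the scatter), is modest but is a different change, hydroxy in place of methyl, at another place. For the measured compounds named here, no measured step involves cyano or fluoro, so it offers little guidance here. The estimated step is a 1.3-fold higher number from compound 2 to compound 4 (0.10 log units; within the scatter), with nothing expected beyond the scatter in this assay. Compound 4 is expected at 5 ug/mL, with an estimated range of 2 ug/mL to 15 ug/mL.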

Compound 4, solubility: 125 ug/mL
Compound 4: middle estimate off by 25-fold (1.40 log units), on the low side; measured number outside the range, above it.
By their numbers in this assay, from the lowest: compound 2; then compound 1; then compounds 4 and 3 (each within the scatter of the next).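

In this assay, going from 3-cyanophenyl to 3-fluorophenyl comes with a 31-fold higher number from compound 2 to compound 4 (1.49 log units; beyond the scatter), so the read-out is sensitive to what sits at this place, on the aromatic carbon meta to a large group. The earlier step, a 6.5-fold higher number from compound 1 to compound 3 (0.81 log units; beyond the scatter), lay elsewhere on the molecule and said nothing about this position. Nothing measured here accounts for the size of the new step.

Open, as far as these compounds go, is whether a methoxy or an amine at this place would read nearer compound 2 or compound 4. Also open, from the compounds shown here alone, is whether the same change gives a similar step with other groups elsewhere on the core.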